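Sulfate removal from a sulfonium chain: compound 4 from compound 1

The source may hold more compounds than are shown below. What is called first, only, known or untested is meant among the compounds shown, and "the series" means these compounds.

Compound 1 `CCCCCCCC[C@@H](O)[C@H](OS(=O)(=O)[O-])[C@H](O)C[S@+]1C[C@@H](O)[C@H](O)[C@H]1CO`: 1200 nM
Compound 2 `CCCCCC[C@@H](O)[C@H](OS(=O)(=O)[O-])[C@H](O)C[S@+]1C[C@@H](O)[C@H](O)[C@H]1CO`: 1700 nM
Compound 3 `CCC[C@@H](O)[C@H](OS(=O)(=O)[O-])[C@H](O)C[S@+]1C[C@@H](O)[C@H](O)[C@H]1CO`: 4800 nM

In an assay on intestine for inhibition of Maltase-glucoamylase (Homo sapiens) (on this read-out lower numbers stand for stronger inhibition and higher numbers for weaker inhibition), compound 1 has the lowest number of the three, with compound 2 nearest and compound 3 furthest. The steps measured so far all shorten the chain: a 1.4-fold higher number from compound 1 to compound 2 (0.15 log units; within the scatter), a 4.0-fold higher number from compound 1 to compound 3 (0.60 log units; beyond the scatter) and a 2.8-fold higher number from compound 2 to compound 3 (0.45 log units; beyond the scatter). Compound 4 `CCCCCCCC[C@@H](O)[C@H](O)[C@H](O)C[S@+]1C[C@@H](O)[C@H](O)[C@H]1CO` differs from compound 1 otherwise: a hydrogen atom in place of a group of 4 heavy atoms (3 oxygen, 1 sulfur; no ring), on an oxygen on a saturated carbon. None of the measured steps touches this group, so no shown step bears directly on it. Compound 4 is therefore estimated only loosely, as a modest rise, a 3.3-fold higher number from compound 1 to compound 4 (0.52 log units; beyond the scatter). The expected value for compound 4 in this assay is 4000 nM, within a range of 900 nM to 20000 nM.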

Compound 4, half-maximal inhibitory concentration: 2000 nM
Estimate against measurement, compound 4: 2.0-fold (0.30 log units) above; measured number inside the range.
By their numbers in this assay, from the lowest: compounds 1, 2 and 4 (each within the scatter of the next); then compound 3.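

In this assay, a hydrogen atom in place of the group of 4 heavy atoms (3 oxygen, 1 sulfur; no ring), on an oxygen on a saturated carbon, gives a 1.7-fold higher number from compound 1 to compound 4 (0.22 log units; within the scatter). Among the compounds shown here, with this chain, then, the read-out does not depend measurably on that group, whereas the earlier compounds varied only the chain length. Nothing available explains this result.

From the compounds shown here alone, it remains open whether an amine or a carboxylic acid on this carbon would shift the number. Going by these compounds, it is also open whether the same exchange would behave alike on the shorter chain of compound 3.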